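A few compounds are considered here, and "the series" means these few. Any claim that something is new, unique, unknown or untested is made for them only; others in the source may bear on it.

Compound 1 `CC1CCN(C2CCN(S(=O)(=O)c3cccnc3Cl)CC2)CC1` was examined in an ADME assay on HCT-116 cells (Homo sapiens) for cytotoxicity, read by CellTiter-Glo, with a stated time of 72 h; on this read-out lower numbers stand for stronger inhibition and higher numbers for weaker inhibition. In this assay compound 1 gives > 10000 nM, which is a limit of the assay rather than a number. Two further compounds were measured alongside it. Compound 2 `Cc1cc(C)c(S(=O)(=O)N2CCC(N3CCC(CCO)CC3)CC2)c(C)c1` gives > 5000 nM in this assay, again only a limit. Compound 3 `CC1CCN(C2CCN(S(=O)(=O)c3ccc(Br)cc3OC(F)(F)F)CC2)CC1` gives > 5000 nM in this assay, likewise a limit. Compound 1 therefore sits at the limit of > 10000 nM in this assay, at which 1 of the 3 values shown sits, while the other two sit at the limit of > 5000 nM in this assay, at which 2 of the 3 values shown sit; none of the three is pinned to a number, and nothing orders them.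

Compound 4 `CC1CCN(C2CCN(S(=O)(=O)c3cccc(Cl)c3)CC2)CC1` has not yet been measured in this assay. It differs from compound 1 in a single place: 3-chlorophenyl in place of 2-chloropyridin-3-yl on a sulfonyl sulfur. Among the compounds with values here, no pair of measured compounds that differ in one place is available, so the effect of this change cannot be read from any measured step. Given that compound 1 gives > 10000 nM, the author expects no step beyond the scatter, estimating a step that the limit leaves unreadable from compound 1 to compound 4. Compound 4 is expected to give 20000 nM in this assay, within a range of 7000 nM to 60000 nM, most likely reported again as a limit.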

Compound 4, half-maximal inhibitory concentration: > 5000 nM
Compound 4 ended at the assay's limit; the forecaster's own chance of this, stated with the estimate: 85%; the middle value does not contradict the limit.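

Within the data shown here, compound 1 and compound 4 both stand at limits in this assay rather than at numbers, and no step between them can be read. The compounds shown leave open what 3-chlorophenyl in place of 2-chloropyridin-3-yl does, and what change would bring any value off a limit.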